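The source may hold more compounds than are shown below. What is called first, only, known or untested is meant among the compounds shown, and "the series" means these compounds.

Values in an ADME assay on microsomes from liver (Homo sapiens) for metabolic stability, with a stated time of 10 min (a higher number here means that more of the compound is left, a lower number that less of the compound is left), for the compounds measured so far follow
Compound 1 (`CC[C@]1(C(=O)O)CC[C@H](C(=O)N2CC[C@](c3ccc(C(F)(C(F)(F)F)C(F)(F)F)cc3)(S(=O)(=O)c3ccc(F)cc3)C2)CC1`) gives (100%)
Compound 2 (`O=C(O)C1CCC(O)(C(=O)N2CC[C@](c3ccc(C(F)(C(F)(F)F)C(F)(F)F)cc3)(S(=O)(=O)c3ccc(F)cc3)C2)CC1`) gives (100%; 95% (2 entries))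
Compound 3 (`O=C(O)C12CCC(C(=O)N3CC[C@](c4ccc(C(F)(C(F)(F)F)C(F)(F)F)cc4)(S(=O)(=O)c4ccc(F)cc4)C3)(CC1)C2`) gives ("not determined" (no result reported))

Compound 3 therefore has no single number in this assay and cannot be placed against the others. The repeat entries of compound 2 (the several entries of compound 2 in this assay, 100%; 95% (2 entries)) lie within the usual scatter of each other. Compound 4 (`NC(=O)[C@H]1CC[C@H](C(=O)N2CC[C@](c3ccc(C(F)(C(F)(F)F)C(F)(F)F)cc3)(S(=O)(=O)c3ccc(F)cc3)C2)CC1`) carries a change from compound 3: a group of 9 heavy atoms (7 carbon, 1 nitrogen, 1 oxygen; one six-membered non-aromatic ring of carbon only) in place of a group of 10 heavy atoms (8 carbon, 2 oxygen; 2 five-membered non-aromatic rings of carbon only), on a carbonyl carbon (a group of 9 heavy atoms (7 carbon, 1 nitrogen, 1 oxygen; one six-membered non-aromatic ring of carbon only) in place of a group of 10 heavy atoms (8 carbon, 2 oxygen; 2 five-membered non-aromatic rings of carbon only), on a carbonyl carbon is the only difference). For the measured compounds named here, with no number for compound 3, no step can be measured from it. Compound 4 is expected to sit with compound 1 (100%) and compound 2 (100%; 95% (2 entries)), with no shift beyond the scatter in either direction. The estimated value for compound 4 is (93%), with an expected range from (78%) to (100%).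

Correction to the above, with a group of 9 heavy atoms (7 carbon, 1 nitrogen, 1 oxygen; one six-membered non-aromatic ring of carbon only) in place of a group of 10 heavy atoms (8 carbon, 2 oxygen; 2 five-membered non-aromatic rings of carbon only), on a carbonyl carbon used once only:

Values in this assay for the compounds measured so far follow
Compound 1 (`CC[C@]1(C(=O)O)CC[C@H](C(=O)N2CC[C@](c3ccc(C(F)(C(F)(F)F)C(F)(F)F)cc3)(S(=O)(=O)c3ccc(F)cc3)C2)CC1`) gives (100%)
Compound 2 (`O=C(O)C1CCC(O)(C(=O)N2CC[C@](c3ccc(C(F)(C(F)(F)F)C(F)(F)F)cc3)(S(=O)(=O)c3ccc(F)cc3)C2)CC1`) gives (100%; 95% (2 entries))
Compound 3 (`O=C(O)C12CCC(C(=O)N3CC[C@](c4ccc(C(F)(C(F)(F)F)C(F)(F)F)cc4)(S(=O)(=O)c4ccc(F)cc4)C3)(CC1)C2`) gives ("not determined" (no result reported))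

Compound 3 therefore has no single number in this assay and cannot be placed against the others. The repeat entries of compound 2 (the several entries of compound 2 in this assay, 100%; 95% (2 entries)) lie within the usual scatter of each other. Compound 4 (`NC(=O)[C@H]1CC[C@H](C(=O)N2CC[C@](c3ccc(C(F)(C(F)(F)F)C(F)(F)F)cc3)(S(=O)(=O)c3ccc(F)cc3)C2)CC1`) differs from compound 3 on a carbonyl carbon whose other neighbours are an amide-type nitrogen in a ring: a group of 9 heavy atoms (7 carbon, 1 nitrogen, 1 oxygen; one six-membered non-aromatic ring of carbon only) in place of a group of 10 heavy atoms (8 carbon, 2 oxygen; 2 five-membered non-aromatic rings of carbon only), on a carbonyl carbon and the 4-carbamoylcyclohexyl group enters there. With no number for compound 3, no step can be read from it. Compound 4 is expected to sit with compound 1 (100%) and compound 2 (100%; 95% (2 entries)), with no shift beyond the scatter in either direction. The estimated value for compound 4 is (93%), with an expected range from (78%) to (100%).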

Compound 4, percent of the compound remaining: 100%
Beside the measured number, compound 4's estimate is 7 percentage points below it, within the range that was stated.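

In this assay, the 4-carbamoylcyclohexyl group in place of the 4-carboxy-4-ethylcyclohexyl group on a carbonyl carbon gives no change at the digits printed from compound 1 to compound 4 (within the scatter). For the compounds shown here, compounds 1, 2 and 3 all carry a carboxylic acid in this group, whereas compound 4 has none, so this is the first reading at this position without one. Nothing shown here gives a cause for this result. On these data alone, what remains open is how an amine or a longer chain in place of the carbamoyl group would read in this assay.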